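The source may report more compounds than this note shows. Statements on the series, on what has been measured and on what is new or still open speak of the compounds shown alone.

Compound 3 `CCCN1CCC(COC(c2ccccc2)c2ccccc2)CC1` gives 17800 nM in a functional assay on cells (T-cell line, Homo sapiens) for inhibition (on this read-out lower numbers stand for stronger inhibition and higher numbers for weaker inhibition), and so stands as the weakest of the three compounds measured, behind compound 2 `COc1cccc(CCCN2CCC(COC(c3ccccc3)c3ccccc3)CC2)c1` at 1500 nM and compound 1 `Cc1ccc(CCCN2CCC(COC(c3ccccc3)c3ccccc3)CC2)cc1` at 200 nM on the same read-out. Compound 4 `CCCCCCCCN1CCC(COC(c2ccccc2)c2ccccc2)CC1` departs from compound 3 by one change, pentyl in place of hydrogen on a saturated chain carbon, three bonds along the chain from an amine nitrogen in a ring. Within the data shown here, two measured steps touch that same place. In an 89-fold higher number from compound 1 to compound 3 (1.95 log units; beyond the scatter) and in a 12-fold higher number from compound 2 to compound 3 (1.07 log units; beyond the scatter) the hydrogen carries the higher number, and a 7.5-fold higher number from compound 1 to compound 2 (0.88 log units; beyond the scatter) shows that the two groups replacing hydrogen do not read alike. Among the measured compounds shown here, no compound with pentyl at this place has been measured, so a lower number is expected only with caution. The expected change is estimated as an 8.9-fold lower number from compound 3 to compound 4 (0.95 log units; beyond the scatter) in this assay and is closer in size to the smaller of those two steps than to the larger. Compound 4 is thus estimated at 2000 nM with 400 nM to 10000 nM as its expected range.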

Compound 4, half-maximal inhibitory concentration: 700 nM
The estimate for compound 4 lay 2.9-fold (0.46 log units) above the measured number, within the range that was stated.
By their numbers in this assay, from the lowest: compound 1; then compound 4; then compound 2; then compound 3.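

In this assay this position also accepts a chain with no ring: pentyl in place of hydrogen gives a 25-fold lower number from compound 3 to compound 4 (1.41 log units; beyond the scatter) and shows that a phenyl ring is not needed for a lower number here. Pentyl also falls among the two substituted phenyl groups, with a 2.1-fold lower number from compound 2 to compound 4 (0.33 log units; beyond the scatter) against 3-methoxyphenyl and a 3.5-fold higher number from compound 1 to compound 4 (0.54 log units; beyond the scatter) against 4-methylphenyl in the same read-out. The order at this place therefore does not split chains from phenyl groups, as 4-methylphenyl reads lowest while 3-methoxyphenyl reads above pentyl.

The compounds shown leave open how a shorter propyl chain, a longer decyl chain or a pentyl chain carrying an amine would read at this place. Nothing given offers a measured reason for the differences among these groups.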